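Methoxy Added to the Core of Compound 1

This account rests on a few compounds, and the source may have more. Where it says the series, first, only, none or still open, it means among the compounds named here.

This account concerns two measured compounds and one that awaits measurement. Compound 1 `c1ccc2[nH]c(-n3cccn3)cc2c1` and compound 2 `COc1ccc2[nH]c3c4cn[nH]c4c4c(c3c2c1)C(=O)NC4=O` were tested in a functional assay on LoVo cells (Homo sapiens) for cytotoxicity, read by MTT assay, with a stated time of 72 h; on this read-out lower numbers stand for stronger inhibition and higher numbers for weaker inhibition. In this assay compound 1 gives 86000 nM, the higher of the two numbers recorded, while compound 2 gives 42000 nM, a lower number, and the gap between them lies beyond the usual scatter. Compound 2 rests on a different core, so its number says little about what a small change on the core of compound 1 would do.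

Compound 3 `COc1ccc2[nH]c(-n3cccn3)cc2c1` is the next compound to be measured. It differs from compound 1 in a single place: methoxy in place of hydrogen on an aromatic carbon. Among the measured compounds shown here, no pair of measured compounds shows what such a change does here, so there is no step to lean on.

With nothing in the data pointing either way, the step is expected to be small, a 1.2-fold lower number from compound 1 to compound 3 (0.09 log units; within the scatter), and probably not beyond the scatter. Compound 3 is accordingly estimated at 70000 nM, with a plausible range from 25000 nM to 200000 nM.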

Compound 3, half-maximal inhibitory concentration: 70000 nM
Compound 3: the middle estimate sits on the measured number at the digits printed, within the range that was stated.
By their numbers in this assay, from the lowest: compounds 2, 3 and 1 (each within the scatter of the next, the first and the last beyond it).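

In this assay, among the compounds shown here, methoxy in place of hydrogen was read for the first time on the core of compound 1, on an aromatic carbon of a six-membered aromatic ring of carbon only, meta to a fused ring and para to a fused ring. For the compounds shown here, the result is a 1.2-fold lower number from compound 1 to compound 3 (0.09 log units; within the scatter), so at this position the two heavy atoms of methoxy leave compound 3 indistinguishable from compound 1 on this read-out, something the earlier compounds, which shared no such step, could not show. Nothing measured alongside these compounds accounts for this outcome.

From the compounds shown here alone, it remains open whether a different group at this same position, such as an amine, a carboxylic acid or a longer chain, would give a step beyond the scatter. Going by these compounds, it is also open whether methoxy would behave in the same way on another aromatic carbon of the shared core, since this single step speaks for one position and one group only.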